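The source may hold more compounds than are shown below. What is called first, only, known or untested is meant among the compounds shown, and "the series" means these compounds.

Measured compounds:
- compound 1, `COc1cc(-n2cnc3ccc(-c4cccc(N)c4)cc32)cc(OC)c1OC`: in a functional assay on MCF7 cells (Homo sapiens) for antiproliferative activity, read by MTT assay, with a stated time of 72 h (a lower number here means a stronger inhibitor, a higher number a weaker inhibitor), compound 1 gives 180 nM
- compound 2, `COc1cc(-n2cnc3ccc(-c4ccc(Cl)cc4)cc32)cc(OC)c1OC`: in this assay compound 2 gives 1320 nM
- compound 3, `COc1cc(-n2cnc3ccc(-c4cccc([N+](=O)[O-])c4)cc32)cc(OC)c1OC`: in this assay compound 3 gives 4560 nM

Compound 3 holds the highest number of the three in this assay: its nearest neighbour is compound 2, reached by a 3.5-fold higher number from compound 2 to compound 3 (0.54 log units; beyond the scatter), and the furthest is compound 1, reached by a 25-fold higher number from compound 1 to compound 3 (1.40 log units; beyond the scatter). Compound 4, `COc1cc(-n2cnc3ccc(-c4ccc(F)cc4)cc32)cc(OC)c1OC`, differs from compound 3 in one place: 4-fluorophenyl in place of 3-nitrophenyl on an aromatic carbon. The step that bears most directly on this change is a 3.5-fold higher number from compound 2 to compound 3 (0.54 log units; beyond the scatter), which runs the other way from a 4-chlorophenyl to the 3-nitrophenyl; undoing the nitro group should therefore move the number back down by a modest amount. The larger step of a 25-fold higher number from compound 1 to compound 3 (1.40 log units; beyond the scatter) also shows that removing the nitro group is associated with a lower number, though compound 4 brings no amino group. A modest decrease is thus expected for compound 4, about a 3.5-fold lower number from compound 3 to compound 4 (0.55 log units; beyond the scatter), and its value in this assay is estimated at 1300 nM (range 500 nM to 3500 nM).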

Compound 4, half-maximal inhibitory concentration: 1770 nM
Beside the measured number, compound 4's estimate is 1.4-fold (0.13 log units) below it, within the range that was stated.
By their numbers in this assay, from the lowest: compound 1; then compounds 2 and 4 (each within the scatter of the next); then compound 3.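

In this assay, fluoro and chloro on the 4-substituted phenyl could not be told apart (a 1.3-fold higher number from compound 2 to compound 4 (0.13 log units; within the scatter)), so this halogen exchange leaves the number within the scatter. The 4-fluorophenyl group adds a second halogen-bearing comparison against the other two aryl groups: 3-nitrophenyl stands apart from it (a 2.6-fold lower number from compound 3 to compound 4 (0.41 log units; beyond the scatter)), and so does 3-aminophenyl, in the opposite direction (a 9.8-fold higher number from compound 1 to compound 4 (0.99 log units; beyond the scatter)). No measurement offered here explains these differences.

Both of the larger steps change the substituent and its place on the phenyl ring together, so the contribution of each remains unseparated. As far as these compounds go, whether a 4-aminophenyl, a 3-fluorophenyl or a 3-hydroxyphenyl group would follow compound 1 or compound 4 remains open.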